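This account rests on a few compounds, and the source may have more. Where it says the series, first, only, none or still open, it means among the compounds named here.

Three compounds sharing one core were compared in a functional assay on PANC-1 cells (Homo sapiens) for inhibition, read by MTT assay, with a stated time of 24 h, tested at 10 uM; a higher number here means more inhibition at the concentration tested (going by the name of the read-out), a lower number less inhibition. Compound 3 `CC(C)=CCC/C(C)=C/CC1Cc2c(OCCCNC(=O)c3cccs3)cc(=O)n(CCCO)c2CC1(C)C` gives 72.8%, the highest of the three numbers. Compound 1 `CC(C)=CCC1Cc2c(OCCCNC(=O)c3cccs3)cc(=O)n(CCCO)c2CC1(C)C` gives 33.6%, and the step of a number 39.2 percentage points higher from compound 1 to compound 3 (beyond the scatter) is large. Compound 2 `CC(C)=CCC/C(C)=C/CC1Cc2c(OCCCNS(=O)(=O)c3ccc(Cl)cc3)cc(=O)n(CCCO)c2CC1(C)C` gives 14.5%, and the step of a number 58.3 percentage points higher from compound 2 to compound 3 (beyond the scatter) is larger still. Compound 4 `CC(C)=CCC/C(C)=C/CC1Cc2c(OC(=O)Nc3ccc(F)c(F)c3)cc(=O)n(CCCO)c2CC1(C)C` has not yet been measured. It differs from compound 3 by (3,4-difluorophenyl)carbamoyl in place of 3-(((thiophen-2-yl)carbonyl)amino)propyl on an oxygen on an aromatic ring. The step from compound 2 to compound 3 bears on this change: there, too, the group carried at the end of the side chain was exchanged, and the read-out moved by a large margin. Here the whole side chain is replaced, so a step beyond the scatter is expected, and a downward one because compound 3 already gives 72.8%, leaving more room to fall than to rise. The step of a number 32.8 percentage points lower from compound 3 to compound 4 (beyond the scatter) is therefore expected. For compound 4 the value in this assay is estimated at 40%, between 15% and 70%.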

Compound 4, a percentage reported as inhibition, at one concentration (the size of the read-out at that concentration, not a potency): 43.7%
For compound 4 the middle estimate is 3.7 percentage points below the measured one, within the range that was stated.
By their numbers in this assay, from the lowest: compound 2; then compound 1; then compound 4; then compound 3.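

The step of a number 29.1 percentage points lower from compound 3 to compound 4 (beyond the scatter) is the first one shown in which the whole group on the oxygen on the aromatic ring is exchanged, whereas the earlier steps changed only the end of that side chain or the chain on the core. The (3,4-difluorophenyl)carbamoyl and 3-(((thiophen-2-yl)carbonyl)amino)propyl groups each count 11 heavy atoms and 1 hydrogen-bond donor, so this loss of inhibition comes with no change in either count, only with one hydrogen-bond acceptor fewer. Nothing available explains why the number falls.

In this change, the link to the oxygen and the ring at its far end differ together, so their separate contributions cannot be told apart. A thiophen-2-yl carbamoyl, or a 3,4-difluorobenzamide on the propyl chain, would separate them, and a simple amine at the end of that chain remains an untested contrast.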